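This account rests on a few compounds, and the source may have more. Where it says the series, first, only, none or still open, it means among the compounds named here.

Measured compounds:
- compound 1, `COc1cc(C2=NN(C(C)=O)C(c3ccc(F)c(F)c3)O2)cc(OC)c1OC`, 46.9%
- compound 2, `COc1cc(C2=NN(C(C)=O)C(c3ccc(F)cc3)O2)cc(OC)c1OC`, 0.1%
- compound 3, `COc1cc(C2=NN(C(C)=O)C(c3cc(Cl)cc(Cl)c3)O2)cc(OC)c1OC`, 93.9%

In a functional assay on PC-3 cells (Homo sapiens) for antiproliferative activity, read by MTT assay, tested at 5 uM (a higher number here means a stronger effect of the compound at the concentration tested, a lower number a weaker effect), compound 3 gives 93.9%, the highest of the three numbers. The nearest of the others is compound 1 with 46.9%, and the step of a number 47 percentage points higher from compound 1 to compound 3 (beyond the scatter) is large. Compound 2 gives 0.1%, and the step of a number 93.8 percentage points higher from compound 2 to compound 3 (beyond the scatter) is even larger. Between the two smaller compounds, the step of a number 46.8 percentage points lower from compound 1 to compound 2 (beyond the scatter) shows that a single fluoro on the aromatic ring makes a large difference in this assay.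

Compound 4, `COc1cc(C2=NN(C(C)=O)C(c3ccc(Cl)c(Cl)c3)O2)cc(OC)c1OC`, differs from compound 3 in one place: 3,4-dichlorophenyl in place of 3,5-dichlorophenyl on a saturated ring carbon. For the measured compounds named here, no measured step changes the positions of two halogens on this ring while keeping the halogen the same, so the steps from compound 1 and compound 2 to compound 3 bear on it only indirectly. The 3,4-pattern is present in compound 1, whose number sits well below that of compound 3, while both chlorines are kept in compound 4. The expectation is therefore a step of a number 23.9 percentage points lower from compound 3 to compound 4 (beyond the scatter), downward but not all the way to compound 1. Compound 4 is estimated at 70%, in a range from 40% to 95%.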

Compound 4, a percentage reported as inhibition, at one concentration (the size of the read-out at that concentration, not a potency): 26.1%
Compound 4: the middle estimate sits 43.9 percentage points above what was measured; the whole stated range lies above it.
By their numbers in this assay, from the lowest: compound 2; then compound 4; then compound 1; then compound 3.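

In this assay, the step of a number 67.8 percentage points lower from compound 3 to compound 4 (beyond the scatter) shows that the placement of the two chlorines alone can carry a large change at this saturated ring carbon, since 3,4-dichlorophenyl and 3,5-dichlorophenyl hold the same atoms, joined differently. The earlier compounds shown here suggested that chlorine might be the better halogen here, but the step of a number 20.8 percentage points lower from compound 1 to compound 4 (beyond the scatter) goes against this: with the 3,4-pattern kept, 3,4-dichlorophenyl in place of 3,4-difluorophenyl lowers the number, so the high reading of compound 3 cannot be credited to chlorine alone, although the step of a number 26 percentage points higher from compound 2 to compound 4 (beyond the scatter) leaves 3,4-dichlorophenyl modestly above 4-fluorophenyl. No measurement at hand accounts for this sensitivity to the placement of the halogens on the ring.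

From the compounds shown here alone, what stays open is whether the high reading belongs to the 3,5-pattern as such or only to the chlorines in it, a question that 3,5-difluorophenyl, 3,5-dibromophenyl or 3,5-dimethylphenyl at this carbon would address. Also open is whether a group without halogen, such as 3,5-dimethoxyphenyl, would hold up there, and how the order of these compounds would look as potencies rather than as readings at a single concentration.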